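Adding a Phenyl Group to the Core of Compound 2

The compounds below may be only part of what the source reports. "The series", "measured", "known", "first", "only" and "open" are said of these compounds alone.

Compound 1 `CC(C)n1nc(-c2cc(C3CCCCC3)on2)c2c(N)ncnc21` gives in an assay on TT cells for inhibition of proto-oncogene tyrosine-protein kinase receptor Ret variant C634W (Homo sapiens), read by MTT assay, with a stated time of 10 days (on this read-out lower numbers stand for stronger inhibition of growth and higher numbers for weaker inhibition of growth), the value > 10000 nM, which is a limit of the assay.
Compound 2 `CC(C)n1nc(-c2ccon2)c2c(N)ncnc21` gives in this assay the value 7920 nM.
Compound 3 `CC(C)n1nc(/C=N/O)c2c(N)ncnc21` gives in this assay the value > 10000 nM, which is a limit of the assay.

Going by the values given here, compound 2 stands out as the only compound with a measured number in this assay; the other two values are limits, as noted in the limit of > 10000 nM in this assay, at which 2 of the 3 values shown sit. The step from compound 1 to compound 2 removed a cyclohexyl group from an aromatic carbon, and an at least 1.2-fold lower number from compound 1 to compound 2 (0.10 log units; that floor lies within the scatter). The step from compound 2 to compound 3 exchanged the five-membered ring for a smaller group, and an at least 1.2-fold higher number from compound 2 to compound 3 (0.10 log units; that floor lies within the scatter).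

Compound 4 `CC(C)n1nc(-c2cc(-c3ccccc3)on2)c2c(N)ncnc21` is not yet measured. It differs from compound 2 by phenyl in place of hydrogen on an aromatic carbon. The step from compound 1 to compound 2 bears on this change most directly, since both concern a large group on the same aromatic carbon, though its size is only given as a floor within the scatter. Putting a phenyl group onto that carbon is therefore expected to move compound 4 back toward the limit region of compound 1, with an expected step of a 1.9-fold higher number from compound 2 to compound 4 (0.28 log units; within the scatter). Compound 4 is estimated at 15000 nM, within a range from 5000 nM to 40000 nM, and a limit rather than a number is considered the more likely outcome.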

Compound 4, concentration for 50% growth inhibition: > 10000 nM
Compound 4: no number, only a limit; the forecaster's own chance of this, stated with the estimate: 60%; the middle value lies beyond the limit too.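

As far as these compounds go, with phenyl in place of hydrogen on the aromatic carbon next to the ring oxygen, the result is an at least 1.2-fold higher number from compound 2 to compound 4 (0.10 log units; that floor lies within the scatter), so the true size of this change stays unknown. Until now only cyclohexyl had been seen on this carbon, and compound 4 shows that a six-membered aromatic ring of carbon only also ends at a limit of the assay, so the two large rings cannot be told apart here; the step between compound 1 and compound 4 cannot be read, since both values are limits. Compound 2 remains the only compound with a number in this assay, and the set now sits mostly at one ceiling: the limit of > 10000 nM in this assay, at which 3 of the 4 values shown sit.

The compounds shown leave open whether a small group such as methyl, or an amine or a carboxylic acid, on this same carbon would give a readable number in this assay. They also leave open whether any group on this carbon could give a number clearly lower than that of compound 2, which would need a step beyond the scatter.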